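The source may report more compounds than this note shows. Statements on the series, on what has been measured and on what is new or still open speak of the compounds shown alone.

Among the measured compounds shown here, in a functional assay on CFPAC-1 cells (Homo sapiens) for inhibition, read by MTT assay, with a stated time of 72 h (on this read-out lower numbers stand for stronger inhibition and higher numbers for weaker inhibition), compound 3 `CCCCCCCCc1cn(Cc2cc(=O)oc3cc(O)ccc23)nn1` gives 62700 nM, the only number among the three measured compounds. Compound 1 `O=c1cc(Cn2cc(C3CC3)nn2)c2ccc(O)cc2o1` gives > 100000 nM in this assay, which is a limit of the assay and not a number. Compound 2 `O=c1cc(Cn2cc(CCO)nn2)c2ccc(O)cc2o1` gives > 100000 nM in this assay, again a limit. The step from compound 1 to compound 2 stays unreadable because the limit of > 100000 nM in this assay, at which 2 of the 3 values shown sit, holds both of its ends, and it is recorded as a step that the two limits leave unreadable from compound 1 to compound 2. Two steps can be read: an at least 1.5-fold lower number from compound 1 to compound 3 (0.20 log units; that floor lies within the scatter) and an at least 1.5-fold lower number from compound 2 to compound 3 (0.20 log units; that floor lies within the scatter), both of which change the group on the same aromatic carbon and reach only a floor that lies within the scatter. Compound 4 `O=c1cc(Cn2cc(-c3ccc(Br)cc3)nn2)c2ccc(O)cc2o1` differs from compound 3 by 4-bromophenyl in place of octyl on an aromatic carbon. Since both readable steps into compound 3 alter that carbon without a movement beyond the scatter, the expected step in this assay from compound 3 to compound 4 is a 1.3-fold lower number from compound 3 to compound 4 (0.10 log units; within the scatter), a change not beyond the scatter. Compound 4 is therefore estimated at 50000 nM, with a range from 15000 nM to 150000 nM.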

Compound 4, half-maximal inhibitory concentration: 52900 nM
The estimate for compound 4 lay 1.1-fold (0.02 log units) below the measured number; measured number inside the range.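

At the aromatic carbon of the five-membered ring with 3 nitrogen, a ring can replace a chain without a readable change in this assay: with 4-bromophenyl in place of octyl, the result is a 1.2-fold lower number from compound 3 to compound 4 (0.07 log units; within the scatter). Against 2-hydroxyethyl and cyclopropyl, the 4-bromophenyl group gives an at least 1.8-fold lower number from compound 2 to compound 4 (0.27 log units; that floor lies within the scatter) and an at least 1.8-fold lower number from compound 1 to compound 4 (0.27 log units; that floor lies within the scatter), and both of these floors also stay within the scatter. These two steps reach only a floor because each starts from a limit of the assay, not from a number: the limit of > 100000 nM in this assay, at which 2 of the 4 values shown sit.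

As far as these compounds go, it remains open whether an amine, a carboxylic acid or a chain longer than octyl at this carbon would move the number beyond the scatter. The part played by the bromine also remains open, since a plain phenyl group does not appear among these compounds.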